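Varying the pendant aryl group on a shared kinase-binding core

The source may hold more compounds than are shown below. What is called first, only, known or untested is meant among the compounds shown, and "the series" means these compounds.

Three compounds share one core and differ only in the aryl group attached to it. In an assay for binding affinity to dual specificity mitogen-activated protein kinase kinase 4 (Homo sapiens), read by KINOMEscan, tested at 100 nM (a higher number here means a weaker effect of the compound at the concentration tested, a lower number a stronger effect), compound 1 `CCCS(=O)(=O)Nc1ccc(F)c(C(=O)c2n[nH]c3ncc(-c4ccccc4Cl)cc23)c1F` gives 9.3%, compound 2 `CCCS(=O)(=O)Nc1ccc(F)c(C(=O)c2n[nH]c3ncc(-c4cccc(C)c4)cc23)c1F` gives 15%, and compound 3 `CCCS(=O)(=O)Nc1ccc(F)c(C(=O)c2n[nH]c3ncc(-c4ccc(F)cc4C)cc23)c1F` gives 14%. Compound 3 thus stands second highest of the three, nearest to compound 2 and furthest from compound 1, with both gaps within the scatter. Compound 4 `CCCS(=O)(=O)Nc1ccc(F)c(C(=O)c2n[nH]c3ncc(-c4ccc(OC)cc4Cl)cc23)c1F` carries a further change: 2-chloro-4-methoxyphenyl in place of 4-fluoro-2-methylphenyl on an aromatic carbon. Going by the values given here, the steps that bear on it, a number 4.7 percentage points higher from compound 1 to compound 3 (within the scatter), a number 1 percentage points lower from compound 2 to compound 3 (within the scatter) and a number 5.7 percentage points higher from compound 1 to compound 2 (within the scatter), are all within the scatter, so no step beyond the scatter is expected in this assay. Compound 4 is therefore estimated at 12%, between 4% and 26%, an expected step of a number 2 percentage points lower from compound 3 to compound 4 (within the scatter).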

Compound 4, a percentage reported as activity, at one concentration (the size of the read-out at that concentration, not a potency): 5.3%
For compound 4 the middle estimate is 6.7 percentage points above the measured one, and the stated range covers the measured number.
By their numbers in this assay, from the lowest: compounds 4, 1, 3 and 2 (each within the scatter of the next).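

At this aryl position on the shared core, in this assay, exchanging whole aryl groups for 2-chloro-4-methoxyphenyl still gives only small steps (a number 8.7 percentage points lower from compound 3 to compound 4 (within the scatter)) and (a number 9.7 percentage points lower from compound 2 to compound 4 (within the scatter)), although the entering group carries a hydrogen-bond acceptor that the leaving 4-fluoro-2-methylphenyl lacks. Methoxy in place of hydrogen on the aryl ring of compound 1 also gives only a small step (a number 4 percentage points lower from compound 1 to compound 4 (within the scatter)). Nothing available accounts for the size of these steps.

As far as these compounds go, it remains open whether an amine or a carboxylic acid on this aryl ring, or a longer chain in place of methoxy, would give a step beyond the scatter.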